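A few compounds are considered here, and "the series" means these few. Any claim that something is new, unique, unknown or untested is made for them only; others in the source may bear on it.

Measured compounds in this series:
- compound 1, `COc1ccc(-c2cnc(NC(=O)c3ccccc3F)n2C)cc1`; in a toxicity assay on THP-1 cells (Homo sapiens) for inhibition (on this read-out higher numbers stand for lower toxicity in this test and lower numbers for higher toxicity in this test), compound 1 gives > 100000 nM, a limit of the assay rather than a number.
- compound 2, `Cn1c(-c2ccc(F)cc2)cnc1NC(=O)c1ccc(F)cc1`; compound 2 gives > 100000 nM, again a limit.
- compound 3, `Cc1ccccc1C(=O)Nc1ncc(-c2ccccc2)n1C`; compound 3 gives > 100000 nM, also a limit.

Compound 1 therefore stands at the edge of what this assay resolves, and the three values together sit at the limit of > 100000 nM in this assay, at which 3 of the 3 values shown sit. Nothing separates compound 1 from compound 2 or compound 3 on these numbers.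

Compound 4, `COc1ccc(-c2cnc(NC(=O)c3ccc(Br)cc3)n2C)cc1`, is the next compound to be run. It differs from compound 1 by 4-bromophenyl in place of 2-fluorophenyl on a carbonyl carbon. Among the measured compounds shown here, no step between two measured compounds is available to calibrate this change, and every value so far is a limit, so there is no basis for a directional step in this assay; the expectation is none beyond the scatter. Compound 4 is estimated at 100000 nM, with a range from 50000 nM to 300000 nM, most likely reported again as a limit. The expected step is a number no higher from compound 1 to compound 4 (the limit leaves the size open).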

Compound 4, half-maximal cytotoxic concentration: > 100000 nM
Compound 4: only a limit was reported (the forecaster's own chance of this, stated with the estimate: 85%); the middle value lies on the limit itself.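

Compound 4 gives > 100000 nM, a limit. As compound 1 also stands at a limit, no step can be read between compound 1 and compound 4 in this assay: the limit of > 100000 nM in this assay, at which 4 of the 4 values shown sit. The compounds shown leave open whether any change on the shared core alters toxicity in this assay.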